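This account rests on a few compounds, and the source may have more. Where it says the series, first, only, none or still open, it means among the compounds named here.

Compound 3 `COC(=O)c1ccc(N2C(=O)C=CC2OCC(F)(F)F)cc1` gives 14700 nM in a functional assay on K562 cells (Homo sapiens) for inhibition (a higher number here means a weaker inhibitor, a lower number a stronger inhibitor), the highest of the three numbers in hand. Compound 1 `CCc1ccc(N2C(=O)C=CC2OCC(F)(F)F)cc1` gives 4470 nM in this assay, and compound 2 `O=C1C=CC(OCC(F)(F)F)N1c1ccc([N+](=O)[O-])cc1` gives 1530 nM. Both steps onto compound 3 raise the number: a 3.3-fold higher number from compound 1 to compound 3 (0.52 log units; beyond the scatter) and a 9.6-fold higher number from compound 2 to compound 3 (0.98 log units; beyond the scatter); the step between the other two is a 2.9-fold lower number from compound 1 to compound 2 (0.47 log units; beyond the scatter). Compound 4 `CC(C)(C)c1ccc(N2C(=O)C=CC2OCC(F)(F)F)cc1` is not yet measured in this assay. The change from compound 3 is tert-butyl in place of methoxycarbonyl on an aromatic carbon, the entering group being, like the ethyl of compound 1, an alkyl group with no hydrogen-bond acceptors. The step that bears most directly on it is the reverse of a 3.3-fold higher number from compound 1 to compound 3 (0.52 log units; beyond the scatter), so compound 4 is expected to move back down toward the number of compound 1 rather than on to that of compound 2; a drop as large as a 9.6-fold higher number from compound 2 to compound 3 (0.98 log units; beyond the scatter) run backwards has no support from any alkyl substituent here. The estimate for compound 4 in this assay is 4500 nM, between 1500 nM and 14000 nM, a step of a 3.3-fold lower number from compound 3 to compound 4 (0.51 log units; beyond the scatter) from compound 3.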

Compound 4, half-maximal inhibitory concentration: 70 nM
Compound 4: the middle estimate sits 64-fold (1.81 log units) above what was measured, outside the stated range (below it).
By their numbers in this assay, from the lowest: compound 4; then compound 2; then compound 1; then compound 3.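

Among these compounds, at this aromatic carbon, para to a large group, the swap of methoxycarbonyl for tert-butyl keeps the heavy-atom count unchanged yet gives a 210-fold lower number from compound 3 to compound 4 (2.32 log units; beyond the scatter), far larger than any step among the earlier compounds, so that count alone does not set the number in this assay. Two alkyl groups also part widely, with a 64-fold lower number from compound 1 to compound 4 (1.81 log units; beyond the scatter), so the label "alkyl" does not place a compound in this set, and tert-butyl also passes the previous lowest number, with a 22-fold lower number from compound 2 to compound 4 (1.34 log units; beyond the scatter). Nothing available here accounts for the size of these steps.

The compounds shown leave open whether isopropyl or a longer chain such as n-butyl would fall nearer compound 1 or compound 4. Also open, on these data alone, is how an amine or a carboxylic acid at this carbon would compare.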